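The compounds below may be only part of what the source reports. "The series", "measured", "known", "first", "only" and "open" are said of these compounds alone.

Series notes. Compound 1 `O=S(=O)(c1ccc(-c2cnc(C3CC3)o2)cc1)N1CCCOc2cc(F)ccc21` and compound 2 `O=[N+]([O-])c1ccc2c(c1)OCCCN2S(=O)(=O)c1ccc(-c2cnc(C3CC3)o2)cc1` share one core and differ at a single aromatic carbon: fluoro in place of nitro on an aromatic carbon. In a functional assay on SK-OV-3 cells (Homo sapiens) for antiproliferative activity, read by MTT assay, with a stated time of 72 h (on this read-out lower numbers stand for stronger inhibition and higher numbers for weaker inhibition), compound 2 gives 120 nM, and compound 1 gives 28 nM, so the change makes a 4.3-fold lower number from compound 2 to compound 1 (0.63 log units; beyond the scatter). Compound 3 `O=[N+]([O-])c1ccc2c(c1)N(S(=O)(=O)c1ccc(-c3cnc(C4CC4)o3)cc1)CCCO2` is made of the same atoms as compound 2, joined differently; the difference between the two cores is not broken down here. In this assay compound 3 gives 53 nM, the second highest of the three numbers, within the scatter of compound 1 and beyond the scatter of compound 2.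

Compound 4 `O=S(=O)(c1ccc(-c2cnc(C3CC3)o2)cc1)N1CCCOc2ccc(F)cc21` has not yet been measured in this assay. It differs from compound 3 at one place: fluoro in place of nitro on an aromatic carbon. This is the same change as the one from compound 2 to compound 1, and it occurs twice among the compounds shown. For the measured compounds named here, the only measured example of this change is a 4.3-fold lower number from compound 2 to compound 1 (0.63 log units; beyond the scatter), so the expectation for compound 4 rests on one pair, made on a core whose difference from that of compound 3 is not broken down. With that single example in hand, the expected step is set a little shorter than the measured one: a 2.9-fold lower number from compound 3 to compound 4 (0.47 log units; beyond the scatter). For compound 4 in this assay the estimate is therefore 18 nM, with a range from 7 nM to 45 nM.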

Compound 4, half-maximal inhibitory concentration: 15 nM
Estimate against measurement, compound 4: 1.2-fold (0.08 log units) above, and the stated range covers the measured number.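

Fluoro in place of nitro on an aromatic carbon gives, in this assay, a 3.5-fold lower number from compound 3 to compound 4 (0.55 log units; beyond the scatter), so the change seen on the core of compound 2 recurs on the core of compound 3, and the two steps agree: the same change on two cores in this assay, a 4.3-fold lower number (0.63 log units; beyond the scatter) from compound 2 to compound 1 and a 3.5-fold lower number (0.55 log units; beyond the scatter) from compound 3 to compound 4, 1.2-fold (0.08 log units) apart, within the scatter of two such steps

For these two cores, the step measured on one core was a usable guide to the direction and size of the step on the other, and the difference between the cores does not visibly alter it. For the compounds shown here, this rests on only two matched pairs in a single cell-based read-out: it shows neither that the change would carry over to any further core nor why the fluoro compounds give the lower numbers, and the comparison of steps does not break down what differs between the two cores.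

The compounds shown carry only nitro or fluoro at the substituted aromatic carbon, so it remains open how a group such as chloro, methoxy, nitrile or an amine would behave there on either core. Also open, on these data alone, is whether the step holds on other cell lines or in assays of a different kind.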